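The compounds below may be only part of what the source reports. "The series", "measured", "known", "first", "only" and "open" are said of these compounds alone.

Measured in a functional assay on MCF7 cells (Homo sapiens) for inhibition, read by trypan blue exclusion, with a stated time of 72 h; on this read-out lower numbers stand for stronger inhibition of growth and higher numbers for weaker inhibition of growth:
- compound 1 `CC/C(=C(\c1ccccc1)c1ccc(NC(=O)C(C)C)cc1)c1ccc(Cl)cc1Cl`: 8300 nM
- compound 2 `CC/C(=C(/c1ccccc1)c1ccc(NC(=O)C(C)C)cc1)c1ccccc1`: > 30000 nM (a limit)

Compound 2 has no number in this assay, only the limit > 30000 nM.

Compound 3 `CC/C(=C(/c1ccccc1)c1ccc(NC(=O)C(C)C)cc1)c1ccc(Cl)cc1Cl` is not yet measured. It differs from compound 2 by 2,4-dichlorophenyl in place of phenyl on a double-bonded chain carbon bound to a double-bonded chain carbon and a saturated chain carbon.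

Going by the values given here, no step between measured compounds is available as a guide. Among the compounds with values here, compound 1, the only measured compound carrying 2,4-dichlorophenyl, gives 8300 nM, so the expectation is a change toward stronger inhibition of growth, of moderate size. The expected step is an at least 3.7-fold lower number from compound 2 to compound 3 (0.57 log units; beyond the scatter). For compound 3 the estimated value is 8000 nM, with an expected range of 2500 nM to 25000 nM.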

Compound 3, concentration for 50% growth inhibition: 17500 nM
Estimate against measurement, compound 3: 2.2-fold (0.34 log units) below; the range from low to high includes it.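

In this assay compound 2 has only a limit, > 30000 nM. Placing 2,4-dichlorophenyl in place of phenyl on this double-bonded chain carbon gives an at least 1.7-fold lower number from compound 2 to compound 3 (0.23 log units; that floor lies within the scatter), so the change now has a floor but no fixed size: the limit of > 30000 nM in this assay, at which 1 of the 3 values shown sits.

The double bond also counts in this series, with a 2.1-fold higher number from compound 1 to compound 3 (0.32 log units; beyond the scatter), and this step can be assigned to the configuration alone because nothing else separates the pair: the fact that compounds 1 and 3 differ only in the configuration as drawn

Going by these compounds, it remains open whether a single chlorine, or methoxy groups in place of the two chlorines, would give a similar number at this position. Also open, on these data alone, is how the Z form of compound 2 would compare with compound 1, which would show whether the effect of 2,4-dichlorophenyl holds across both configurations.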